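A few compounds are considered here, and "the series" means these few. Any claim that something is new, unique, unknown or untested is made for them only; others in the source may bear on it.

Three compounds share one core and differ only in the ring attached to the amide. Compound 1 `O=C(Nc1ccc2c(c1)B(O)OC2)c1ccccc1C(F)(F)F` and compound 2 `O=C(Nc1ccc2c(c1)B(O)OC2)c1cccc(C(F)(F)F)c1` are built from the same atoms joined differently; the difference between the two cores is not broken down here. In a functional assay on PBMC cells (Homo sapiens) for inhibition, read by HTRF, with stated times of 15 min and 24 h (on this read-out lower numbers stand for stronger inhibition and higher numbers for weaker inhibition), compound 1 gives 2100 nM. Compound 2 gives only > 10000 nM, which is a limit of this assay and not a number (the limit of > 10000 nM in this assay, at which 1 of the 3 values shown sits). Compound 3 `O=C(Nc1ccc2c(c1)B(O)OC2)c1c(F)cccc1C(F)(F)F` carries an added fluoro relative to compound 1, (fluoro in place of hydrogen on an aromatic carbon). In this assay compound 3 gives 180 nM; the step of a 12-fold lower number from compound 1 to compound 3 (1.07 log units; beyond the scatter) is large. Compound 4 `O=C(Nc1ccc2c(c1)B(O)OC2)c1cccc(C(F)(F)F)c1F` is not yet measured. It arises from compound 2 by the same kind of change, (fluoro in place of hydrogen on an aromatic carbon), but the place is not the same: in compound 3 the fluoro sits meta to a trifluoromethyl group, in compound 4 ortho to a trifluoromethyl group. Going by these compounds, whether a fluoro at this place helps as much is unknown, and the starting point is itself only a limit, so the expected step of an at least 4.0-fold lower number from compound 2 to compound 4 (0.60 log units; beyond the scatter) is taken as smaller than the measured one. Compound 4 is therefore estimated at 2500 nM, with a plausible range from 600 nM to 10000 nM.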

Compound 4, half-maximal inhibitory concentration: > 100000 nM
Compound 4 gave a limit, no number (the forecaster's own chance of this, stated with the estimate: 35%); at least 40-fold (1.60 log units) between middle value and limit.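

Compound 2 stands at a limit, not a number: the limit of > 10000 nM in this assay, at which 1 of the 4 values shown sits.

Compound 4 also stands at a limit, not a number: the limit of > 100000 nM in this assay, at which 1 of the 4 values shown sits.

Among the compounds shown here, with only these two limits, no step from compound 2 to compound 4 can be read. The compounds shown leave open how strongly either one inhibits, and whether a fluoro ortho to a trifluoromethyl group changes inhibition at all.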